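Double-bond configuration at the assay limit

This account rests on a few compounds, and the source may have more. Where it says the series, first, only, none or still open, it means among the compounds named here.

- compound 1 `COc1ccc(/C=C\c2ccc3ccccc3c2)cc1N`: > 20000 nM (a limit)
- compound 2 `O=S(=O)(c1ccccc1)n1ccc2cc(/C=C/c3ccc4ccccc4c3)ccc21`: > 5000 nM (a limit)

Both compounds were tested in a functional assay on SK-MEL-28 cells (Homo sapiens) for inhibition (on this read-out higher numbers stand for weaker inhibition and lower numbers for stronger inhibition), and neither gave a number. Compound 2 stands at > 5000 nM as a limit in this assay and offers no exact starting point.

The next compound is compound 3 `O=S(=O)(c1ccccc1)n1ccc2cc(/C=C\c3ccc4ccccc4c3)ccc21`. The change is the two compounds have the same atoms and bonds and differ only in configuration as drawn: 1 of 1 stereo elements differ; a double bond is drawn E in compound 2 and Z in compound 3 and nothing else. For the measured compounds named here, no measured pair shows what such a change does in this assay, so the size of the step cannot be read from the data. Compound 1 also carries a double bond drawn Z, and its > 20000 nM is likewise a limit. On that basis, no large move towards stronger inhibition is expected, only a modest one at best. The expected change is a step that the limit leaves unreadable from compound 2 to compound 3 and remains uncertain. Compound 3 is estimated at 6000 nM with an expected range of 800 nM to 20000 nM in this assay and could equally return only a limit.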

Compound 3, half-maximal inhibitory concentration: > 5000 nM
Compound 3 ended at the assay's limit; the forecaster's own chance of this, stated with the estimate: 50%; the middle value does not contradict the limit.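

In this assay compound 3 gives > 5000 nM, which is a limit. For the compounds shown here, compound 2 also stands at a limit, so no step between compound 2 and compound 3 can be read. The compounds shown leave open whether the E or the Z double bond gives stronger inhibition in this assay.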